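The compounds below may be only part of what the source reports. "The series", "measured", "known", "first", "only" and "open" are said of these compounds alone.

Measured compounds:
Compound 1 `Cc1nc(-c2ccccc2)c(C(=O)N2CCN(c3cccc(C(N)=O)c3)CC2)o1` gives 71 nM in a functional assay on HL-60 cells (Homo sapiens) for inhibition, read by MTT assay, with a stated time of 72 h; on this read-out lower numbers stand for stronger inhibition and higher numbers for weaker inhibition.
Compound 2 `Cc1nc(-c2ccccc2)c(C(=O)N2CCN(c3ccc(Cl)c(Cl)c3)CC2)o1` gives 124 nM in this assay.
Compound 3 `Cc1nc(-c2ccccc2)c(C(=O)N2CCN(c3ccccc3)CC2)o1` gives 39.1 nM in this assay.

Of these three numbers compound 3 has the lowest. The step of a 1.8-fold lower number from compound 1 to compound 3 (0.26 log units; within the scatter) lies within the scatter, so no order between the two can be claimed; the step of a 3.2-fold lower number from compound 2 to compound 3 (0.50 log units; beyond the scatter) is beyond the scatter.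

The next compound, compound 4 `Cc1nc(-c2ccccc2)c(C(=O)N2CCN(c3ccccc3C(F)(F)F)CC2)o1`, keeps the shared core and differs from compound 3 in one place: trifluoromethyl in place of hydrogen on an aromatic carbon. For the measured compounds named here, the steps that bear on this change are those in which the plain phenyl on the ring nitrogen was decorated. Putting a carbamoyl on it, as in compound 1, moved the number by a 1.8-fold lower number from compound 1 to compound 3 (0.26 log units; within the scatter) read in reverse, which is within the scatter; putting two chlorines on it, as in compound 2, moved it by a 3.2-fold lower number from compound 2 to compound 3 (0.50 log units; beyond the scatter) read in reverse, a modest rise. Neither decoration lowered the number. The account therefore expects for compound 4 a step in this assay of a 1.8-fold higher number from compound 3 to compound 4 (0.25 log units; within the scatter), upward and of roughly the size seen with compound 2, though a step within the scatter cannot be excluded. The estimate for compound 4 in this assay is 70 nM, with a range from 30 nM to 160 nM.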

Compound 4, half-maximal inhibitory concentration: 120 nM
Estimate against measurement, compound 4: 1.7-fold (0.23 log units) below; the measured number falls inside the stated range.
By their numbers in this assay, from the lowest: compounds 3, 1, 4 and 2 (each within the scatter of the next, the first and the last beyond it).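

Measured in this assay, the change shows a 3.1-fold higher number from compound 3 to compound 4 (0.49 log units; beyond the scatter), so a single trifluoromethyl on an aromatic carbon, ortho to a large group, is enough to shift the number beyond the scatter, whereas the one-group carbamoyl change in compound 1 stayed within it. The 2-(trifluoromethyl)phenyl group cannot be told apart from the two earlier decorated rings, with a 1.0-fold lower number from compound 2 to compound 4 (0.01 log units; within the scatter) and a 1.7-fold higher number from compound 1 to compound 4 (0.23 log units; within the scatter), both within the scatter, so no order among these three can be claimed. Compound 2 and compound 4 now both stand beyond the scatter from compound 3, while compound 1 does not, and no information bearing on the reason for this step is available.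

The compounds shown leave open whether the rise belongs to trifluoromethyl itself or would also appear with a smaller group at this place, such as a methyl, a methoxy or a single fluorine. They also leave open how 4-(trifluoromethyl)phenyl or 3-(trifluoromethyl)phenyl would compare with the 2-(trifluoromethyl)phenyl group.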